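Pyrazole carbaldehydes: aryl methyl-to-chloro swap on the second core

The source may hold more compounds than are shown below. What is called first, only, known or untested is meant among the compounds shown, and "the series" means these compounds.

Measured so far in a functional assay on NPC-TW01 cells (Homo sapiens) for inhibition, read by MTT assay, with a stated time of 72 h; a higher number here means a weaker inhibitor of growth, a lower number a stronger inhibitor of growth:
compound 1, `Cc1ccc(-c2nn(-c3cccc(Cl)c3)c(/N=C/N(C)C)c2C=O)cc1`, 7200 nM
compound 2, `CN(C)/C=N/c1c(C=O)c(-c2ccc(Cl)cc2)nn1-c1cccc(Cl)c1`, 7400 nM
compound 3, `Cc1ccc(-c2nn(-c3ccc(Br)cc3)c(N)c2C=O)cc1`, 28200 nM

Compounds 1 and 2 share one core and differ in one place: chloro in place of methyl on an aromatic carbon. The step that accompanies it is a 1.0-fold higher number from compound 1 to compound 2 (0.01 log units; within the scatter), so the two numbers are not distinguishable here. Compound 3 stands on a second core; how that core differs from the core of compound 1 is not broken down here, and compound 3 gives the highest of the three numbers, beyond the scatter from both compound 1 and compound 2.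

Compound 4, `Nc1c(C=O)c(-c2ccc(Cl)cc2)nn1-c1ccc(Br)cc1`, is not yet measured. It differs from compound 3 as follows: chloro in place of methyl on an aromatic carbon. Within the data shown here, this is the same change as the one from compound 1 to compound 2, made at the same place. Because that earlier step was a 1.0-fold higher number from compound 1 to compound 2 (0.01 log units; within the scatter), the step from compound 3 to compound 4 is expected to be similarly small, roughly a 1.0-fold lower number from compound 3 to compound 4 (0.02 log units; within the scatter). Compound 4 is therefore estimated at about 27000 nM in this assay, between 12000 nM and 60000 nM.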

Compound 4, concentration for 50% growth inhibition: 59700 nM
For compound 4 the middle estimate is 2.2-fold (0.34 log units) below the measured one; the range from low to high includes it.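

In this assay, chloro in place of methyl on the second core gives a 2.1-fold higher number from compound 3 to compound 4 (0.33 log units; beyond the scatter), a modest weakening, while the same change on the first core gives a 1.0-fold higher number from compound 1 to compound 2 (0.01 log units; within the scatter). The two steps cannot be told apart, so these data give no sign that the core alters the outcome of this change: the same change on two cores in this assay, a 1.0-fold higher number (0.01 log units; within the scatter) from compound 1 to compound 2 and a 2.1-fold higher number (0.33 log units; beyond the scatter) from compound 3 to compound 4, 2.1-fold (0.31 log units) apart, within the scatter of two such steps

This does not show that the steps are equal, and two pairs of compounds say nothing about how the change behaves on any further core.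

Still open, from the compounds shown here alone, is whether a fluoro, methoxy or trifluoromethyl group at this place would track similarly on both cores. Also open, going by these compounds, is whether a carboxylic acid or an amine there would do so.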